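This account rests on a few compounds, and the source may have more. Where it says the series, first, only, none or still open, it means among the compounds named here.

Compound 3 `O=C(NCc1ccncc1)c1c(O)c2cccnc2n(-c2ccccc2)c1=O` stands second highest of the three numbers in a functional assay on the whole organism for inhibition, with Rattus norvegicus as the target, read by cytopathic effect and paw edema, at a dose of 100 mg/kg by the oral route (on this read-out lower numbers stand for less inhibition and higher numbers for more inhibition at the one dose given (going by the name of the read-out)), where compound 3 gives 15.4%. Compound 2 `O=C(Nc1cccnc1)c1c(O)c2cccnc2n(-c2ccccc2)c1=O` gives 30.8%, and compound 1 `O=C(Nc1ccc(Cl)cc1)c1c(O)c2cccnc2n(-c2ccccc2)c1=O` gives 2.5%. The step to compound 4 `COc1ccc(NC(=O)c2c(O)c3cccnc3n(-c3ccccc3)c2=O)cn1` is 6-methoxypyridin-3-yl in place of (pyridin-4-yl)methyl on an amide-type nitrogen. The step that bears on it most closely runs the opposite way, a number 15.4 percentage points lower from compound 2 to compound 3 (beyond the scatter), where pyridin-3-yl on the amide-type nitrogen gave way to (pyridin-4-yl)methyl; the steps of a number 28.3 percentage points higher from compound 1 to compound 2 (beyond the scatter) and a number 12.9 percentage points higher from compound 1 to compound 3 (beyond the scatter) both show the amides bearing pyridin-3-yl or (pyridin-4-yl)methyl standing above the one bearing 4-chlorophenyl. Since compound 4 again carries a pyridin-3-yl type group directly on that nitrogen, an upward step of roughly the reversed size is expected, a number 11.6 percentage points higher from compound 3 to compound 4 (beyond the scatter). Compound 4 is therefore estimated at 27%, between 8% and 46%.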

Compound 4, a percentage reported as inhibition, in the whole organism at one dose (the size of the read-out at that dose, not a potency): -10.2%
Compound 4: middle estimate off by 37.2 percentage points, on the high side, and the stated range ends above it.
By their numbers in this assay, from the lowest: compound 4; then compound 1; then compound 3; then compound 2.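

In this assay the change a number 41 percentage points lower from compound 2 to compound 4 (beyond the scatter) comes from methoxy in place of hydrogen on an aromatic carbon alone, so a pyridin-3-yl type group on the amide-type nitrogen does not by itself keep the number high. With a number 25.6 percentage points lower from compound 3 to compound 4 (beyond the scatter) and a number 12.7 percentage points lower from compound 1 to compound 4 (beyond the scatter) as well, 6-methoxypyridin-3-yl stands below both (pyridin-4-yl)methyl and 4-chlorophenyl at this position. Nothing given here explains the drop.

On these data alone, what an amine, a carboxylic acid or a longer alkoxy chain in place of methoxy would give stays open, as does whether the drop is specific to methoxy.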